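Swapping a cyclic ether onto a Bcl-2 sulfonamide

A few compounds are considered here, and "the series" means these few. Any claim that something is new, unique, unknown or untested is made for them only; others in the source may bear on it.

Three compounds have been measured in an assay on isolated protein for displacement of a labelled ligand from Apoptosis regulator Bcl-2 (Homo sapiens), with a stated time of 15 min; on this read-out lower numbers stand for stronger inhibition and higher numbers for weaker inhibition:
compound 1, `CC1(C)CCC(CN2CCN(c3ccc(C(=O)NS(=O)(=O)c4ccc(NCC5CCOCC5)c([N+](=O)[O-])c4)c(Oc4cnc5[nH]ccc5c4)c3)CC2)=C(c2ccc(C(F)(F)F)cc2)C1`, gives 1.5 nM;
compound 2, `CN(C)CCCNc1ccc(S(=O)(=O)NC(=O)c2ccc(N3CCN(CC4=C(c5ccc(C(F)(F)F)cc5)CC(C)(C)CC4)CC3)cc2Oc2cnc3[nH]ccc3c2)cc1[N+](=O)[O-]`, gives 0.89 nM;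
compound 3, `CC(C)C(=O)N1CCC(CNc2ccc(S(=O)(=O)NC(=O)c3ccc(N4CCN(CC5=C(c6ccc(C(F)(F)F)cc6)CC(C)(C)CC5)CC4)cc3Oc3cnc4[nH]ccc4c3)cc2[N+](=O)[O-])CC1`, gives 2.4 nM.

Among the measured compounds shown here, of these three numbers, the one for compound 3 is the largest. The step of a 1.6-fold higher number from compound 1 to compound 3 (0.20 log units; within the scatter) stays within the scatter, so compound 1 and compound 3 cannot be told apart, whereas the step of a 2.7-fold higher number from compound 2 to compound 3 (0.43 log units; beyond the scatter) goes beyond it. The third measured step, a 1.7-fold lower number from compound 1 to compound 2 (0.23 log units; within the scatter), is also within the scatter.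

Compound 4, `CC1(C)CCC(CN2CCN(c3ccc(C(=O)NS(=O)(=O)c4ccc(NCC5CCOC5)c([N+](=O)[O-])c4)c(Oc4cnc5[nH]ccc5c4)c3)CC2)=C(c2ccc(C(F)(F)F)cc2)C1`, has not been measured. It differs from compound 3 in one place: oxolan-3-yl in place of 1-(isopropylcarbonyl)piperidin-4-yl on a saturated chain carbon bound to a nitrogen on an aromatic ring. The group that enters is a small cyclic ether, and compound 1 already carries a cyclic ether at the same place, so the step of a 1.6-fold higher number from compound 1 to compound 3 (0.20 log units; within the scatter) is the closest guide; read backwards, it suggests that replacing the piperidine-bearing group with a cyclic ether shifts the number slightly downward, but not beyond the scatter. The estimate for compound 4 in this assay is therefore 1.6 nM, with a likely range from 0.7 nM to 3.5 nM. The expected step of a 1.5-fold lower number from compound 3 to compound 4 (0.18 log units; within the scatter) would be a small one, within the scatter.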

Compound 4, half-maximal inhibitory concentration: 4.7 nM
The estimate for compound 4 lay 2.9-fold (0.47 log units) below the measured number; measured number outside the range, above it.
By their numbers in this assay, from the lowest: compounds 2, 1, 3 and 4 (each within the scatter of the next, the first and the last beyond it).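

In this assay, two cyclic ethers at this place do not read alike: a 3.1-fold higher number from compound 1 to compound 4 (0.50 log units; beyond the scatter) lies beyond the scatter, so the presence of a cyclic ether on a saturated chain carbon bound to a nitrogen on an aromatic ring does not by itself set the number. The widest step among these compounds is now a 5.3-fold higher number from compound 2 to compound 4 (0.72 log units; beyond the scatter) and it exceeds the earlier 2.7-fold higher number from compound 2 to compound 3 (0.43 log units; beyond the scatter) among the groups at this place. By contrast, a 2.0-fold higher number from compound 3 to compound 4 (0.29 log units; within the scatter) stays within the scatter, so oxolan-3-yl, with 5 heavy atoms, cannot be told apart from 1-(isopropylcarbonyl)piperidin-4-yl, with more heavy atoms, and heavy-atom count alone does not sort these two groups.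

Nothing available accounts for the separation between the two ethers. Still open, as far as these compounds go, is whether ring size or the point of attachment separates them, a question that an oxan-3-yl group at this place could help to answer, and how a primary amine on the same chain carbon would read.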